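Swapping the ring on the triazole nitrogen: methylphenyl to fluorophenyl

The compounds below may be only part of what the source reports. "The series", "measured", "known", "first", "only" and "open" are said of these compounds alone.

Of the compounds shown here, three that share one core have been tested in a functional assay on SGC-7901 cells (Homo sapiens) for antiproliferative activity, read by MTT assay, with a stated time of 24 h; on this read-out lower numbers stand for stronger inhibition and higher numbers for weaker inhibition. Compound 1 `O=c1[nH]cc(S(=O)(=O)Nc2ccccc2-c2cn(-c3ccccc3Cl)nn2)c(=O)[nH]1` gives 6520 nM. Compound 2 `O=c1[nH]cc(S(=O)(=O)Nc2cccc(-c3cn(-c4ccccc4)nn3)c2)c(=O)[nH]1` gives 17200 nM. Compound 3 `Cc1cccc(-n2cc(-c3cccc(NS(=O)(=O)c4c[nH]c(=O)[nH]c4=O)c3)nn2)c1` gives 9100 nM, which places compound 3 second highest of the three numbers; its value and that of compound 1 lie within the scatter of each other, as do its value and that of compound 2, so no ordering among the three can be claimed.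

Among the measured compounds shown here, the only single-point step among them is a 1.9-fold lower number from compound 2 to compound 3 (0.28 log units; within the scatter), a methyl in place of a hydrogen on an aromatic carbon, and it stays within the scatter.

Compound 4 `O=c1[nH]cc(S(=O)(=O)Nc2cccc(-c3cn(-c4ccccc4F)nn3)c2)c(=O)[nH]1` differs from compound 3 by 2-fluorophenyl in place of 3-methylphenyl on an aromatic nitrogen, that is, on an aromatic nitrogen of a five-membered aromatic ring with three nitrogens. For the measured compounds named here, no measured step exchanges a 3-methylphenyl for a 2-fluorophenyl at this position, so the only guide is that removing the methyl returns toward the value of compound 2, while compound 1, which carries a 2-chlorophenyl on the same kind of nitrogen but with the sulfonamide attached elsewhere, shows a number near that of compound 3. The step is therefore expected to be a 1.3-fold higher number from compound 3 to compound 4 (0.12 log units; within the scatter), within the scatter. Compound 4 is estimated at 12000 nM, with a range from 5000 nM to 30000 nM in this assay.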

Compound 4, half-maximal inhibitory concentration: 16000 nM
For compound 4 the middle estimate is 1.3-fold (0.12 log units) below the measured one; low and high end bracket the measured number.
By their numbers in this assay, from the lowest: compounds 1, 3, 4 and 2 (each within the scatter of the next, the first and the last beyond it).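

In this assay the exchange of 3-methylphenyl for 2-fluorophenyl on the aromatic nitrogen gives a 1.8-fold higher number from compound 3 to compound 4 (0.25 log units; within the scatter), and the exchange of phenyl for 2-fluorophenyl on that same nitrogen gives a 1.1-fold lower number from compound 2 to compound 4 (0.03 log units; within the scatter). Among the compounds shown here, until now only one pair at this position could be compared; with compound 4, phenyl, 3-methylphenyl and 2-fluorophenyl can all be compared with one another, and no pair among compounds 2, 3 and 4 differs beyond the scatter, so these three rings cannot be told apart here. No independent information is available on what lies behind these small steps.

On these data alone, what happens with a quite different group at this position remains open: an amine or a carboxylic acid on the ring, or a longer chain in place of the ring, might or might not produce a step beyond the scatter. Also open, as far as these compounds go, is whether fluoro and methyl would behave alike if each were compared at the same place on the ring, since the two sit at different ring positions in compound 3 and compound 4.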